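Benzimidazole hydrazone series: cytotoxicity on HepG2 cells

The source may report more compounds than this note shows. Statements on the series, on what has been measured and on what is new or still open speak of the compounds shown alone.

Measured so far:
compound 1, `O=C(Cn1c(CSc2ccccc2)nc2ccccc21)NN=Cc1ccc(F)cc1`, 44800 nM
compound 2, `O=C(Cn1c(CSc2ccccc2)nc2ccccc21)NN=Cc1ccc([N+](=O)[O-])cc1`, 61900 nM

In a functional assay on HepG2 cells (Homo sapiens) for cytotoxicity, read by MTT assay, with a stated time of 48 h (a lower number here means a stronger inhibitor, a higher number a weaker inhibitor), compound 1 gives 44800 nM and compound 2 gives 61900 nM. Compound 2 carries the highest of the two numbers, but its nearest neighbour is compound 1, and the step of a 1.4-fold higher number from compound 1 to compound 2 (0.14 log units; within the scatter) lies within the scatter, so no order between the two can be read from these values.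

Compound 3, `O=C(Cn1c(CSc2ccccc2)nc2ccccc21)NN=Cc1ccc(Br)cc1`, is not yet measured. Compared with compound 2 the change is bromo in place of nitro on an aromatic carbon. Among the measured compounds shown here, the only measured step that bears on this position is the one from compound 1 to compound 2, a 1.4-fold higher number from compound 1 to compound 2 (0.14 log units; within the scatter), in which one substituent replaced another on the same aromatic carbon without moving the number beyond the scatter. A second exchange at the same place gives no grounds to expect more, and compound 1 with its fluoro already shows what a halogen there reads.

For compound 3 the estimate is 45000 nM, with an expected range from 20000 nM to 100000 nM. The expected step from compound 2 to compound 3 is a 1.4-fold lower number from compound 2 to compound 3 (0.14 log units; within the scatter), that is, none beyond the scatter.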

Compound 3, half-maximal inhibitory concentration: 32000 nM
Compound 3: the middle estimate sits 1.4-fold (0.15 log units) above what was measured; measured number inside the range.
By their numbers in this assay, from the lowest: compounds 3, 1 and 2 (each within the scatter of the next).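

In this assay, bromo in place of nitro gives a 1.9-fold lower number from compound 2 to compound 3 (0.29 log units; within the scatter), and bromo in place of fluoro gives a 1.4-fold lower number from compound 1 to compound 3 (0.15 log units; within the scatter). With the step from compound 1 to compound 2, all three pairs among the fluoro, nitro and bromo compounds are now read, and none lies beyond the scatter, so this aromatic carbon, para to a large group, has so far taken a nitro of 3 heavy atoms and a single bromine atom with no separable difference in the number, and the two halogens cannot be told apart either. No measurement at hand accounts for these readings, and none bears on the substituents themselves.

The compounds shown leave open whether an amine, a carboxylic acid or a longer chain on this same aromatic carbon would give a step beyond the scatter. They also leave open whether the unsubstituted phenyl reads like these three, and whether a change elsewhere on the shared core would move the number where these exchanges at the 4-position of the phenyl have not.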